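A chlorophenyl swap on a compound at the limit

The source may hold more compounds than are shown below. What is called first, only, known or untested is meant among the compounds shown, and "the series" means these compounds.

In a functional assay on SMMC-7721 cells (Homo sapiens) for cytotoxicity, read by MTT assay, with a stated time of 72 h (a lower number here means a stronger inhibitor, a higher number a weaker inhibitor), compound 1 `COc1cc(C=C2C(=O)N(c3ccc(Cl)cc3)N(c3ccc(Cl)cc3)C2=O)ccc1O` gives 64900 nM. Compound 2 `COc1ccc(C=C2C(=O)N(c3ccc(Cl)cc3)N(c3ccc(Cl)cc3)C2=O)cc1` reads > 128000 nM, which is a limit of the assay and not a number. Compound 3 `O=C1C(=Cc2cccc(Cl)c2)C(=O)N(c2ccc(Cl)cc2)N1c1ccc(Cl)cc1` carries 3-chlorophenyl in place of the 4-methoxyphenyl of compound 2: 3-chlorophenyl in place of 4-methoxyphenyl on a double-bonded chain carbon bound to a double-bonded ring carbon. Among the compounds with values here, the only measured step that bears on this is an at least 1.9-fold higher number from compound 1 to compound 2 (0.29 log units; that floor lies within the scatter), made at the same place, and its floor lies within the scatter. Only a small move toward a lower number is therefore expected in this assay, and the estimated step is an at least 1.6-fold lower number from compound 2 to compound 3 (0.20 log units; that floor lies within the scatter). The expected value for compound 3 is 80000 nM, within an estimated range of 30000 nM to 128000 nM.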

Compound 3, half-maximal inhibitory concentration: 20200 nM
Compound 3: middle estimate off by 4.0-fold (0.60 log units), on the high side; the measured number lies below the stated range.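

In this assay, this place on the double-bonded chain carbon turns out to respond beyond the scatter: 3-chlorophenyl in place of 4-methoxyphenyl gives an at least 6.3-fold lower number from compound 2 to compound 3 (0.80 log units; beyond the scatter). Replacing 4-hydroxy-3-methoxyphenyl with 3-chlorophenyl also gives a 3.2-fold lower number from compound 1 to compound 3 (0.51 log units; beyond the scatter). The first of these steps can be stated only as a floor because compound 2 reads as a limit of the assay and not a number: the limit of > 128000 nM in this assay, at which 1 of the 3 values shown sits.

The compounds shown cannot separate the effect of the chlorine itself from that of where it sits on the ring. Going by these compounds, how a phenyl ring bearing an amine or a carboxylic acid would read here also remains open.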